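This account rests on a few compounds, and the source may have more. Where it says the series, first, only, none or still open, it means among the compounds named here.

Three compounds have so far been measured in a functional assay on A 172 cells (Homo sapiens) for cytotoxicity, read by colorimetric assay and MTT assay; a higher number here means a weaker inhibitor, a lower number a stronger inhibitor:

Compound 1 `COc1cc(OC)c2cc(-c3ccccc3)c(O)nc2c1`: 10000 nM
Compound 2 `COc1ccc(-c2cc3c(OC)ccc(OC)c3nc2O)cc1`: 10000 nM
Compound 3 `CCOC(=O)Cn1c(=O)c(-c2ccc(OC)cc2)cc2c(OC)cc(OC)cc21`: 10000 nM

In this assay compound 3 gives 10000 nM, which places it level with compound 1 and compound 2, with nothing in the numbers to separate the three.

Compound 4 `CCN(CC)C(=O)Cn1c(=O)c(-c2ccc(OC)cc2)cc2c(OC)cc(OC)cc21` awaits its measurement. It keeps the rest of compound 3 and carries diethylamino in place of ethoxy on a carbonyl carbon. The same difference can be read as ethoxycarbonyl to diethylcarbamoyl.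

For the measured compounds named here, no two measured compounds differ in one place only, so the data give no direct guide to the size of such a change. Going by the values given here, the one available anchor is compound 3 at 10000 nM, and the identical readings of its two companions give no hint of a trend. No step beyond the scatter is therefore expected in this assay, and neither direction is favoured. The expected step, no change at the digits printed from compound 3 to compound 4 (within the scatter), is estimated to stay within the scatter. For compound 4 the estimated value is 10000 nM, with an expected range from 4000 nM to 20000 nM.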

Compound 4, half-maximal inhibitory concentration: 10000 nM
Compound 4: middle estimate and measured number agree at the digits printed; measured number inside the range.
By their numbers in this assay, from the lowest: compounds 1, 2, 3 and 4 (each within the scatter of the next).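

For the compounds shown here, the replacement of ethoxycarbonyl by diethylcarbamoyl gives the first comparison of compounds that differ in one place in this assay, and it reads no change at the digits printed from compound 3 to compound 4 (within the scatter). The entering diethylamino has 5 heavy atoms against 3 for ethoxy and brings nitrogen where ethoxy brought oxygen, yet compound 4 gives 10000 nM, so this exchange on a carbonyl carbon leaves no mark on the reading. Nothing measured here speaks to why the step comes out this way.

As far as these compounds go, how a carboxylic acid or a morpholine amide would read at this carbonyl carbon stays open, as does the reading of a longer chain in place of the (diethylcarbamoyl)methyl group. Also open is whether any change at this place can move a compound away from the value shared by all four, as the compounds shown offer no reading that differs from it.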